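The source may report more compounds than this note shows. Statements on the series, on what has been measured and on what is new or still open speak of the compounds shown alone.

Compound 1 `COc1ccc2c(=O)c(/C=C/C(=O)NCc3cccc(F)c3)coc2c1` gives > 200000 nM in a functional assay on L02 cells (Homo sapiens) for inhibition, read by MTT assay, with a stated time of 48 h (on this read-out lower numbers stand for stronger inhibition and higher numbers for weaker inhibition), a limit of the assay.
Compound 2 `COc1ccc(NC(=O)/C=C/c2coc3cc(OC)ccc3c2=O)cc1` gives > 200000 nM in this assay, also a limit.

Compound 2 thus stands at a limit rather than at a number. For the measured compounds named here, compound 1 sits at the same limit, so the single measured step, a step that the two limits leave unreadable from compound 1 to compound 2, cannot be read. Compound 3 `CCOc1ccc(NC(=O)/C=C/c2coc3cc(OC)ccc3c2=O)cc1` differs from compound 2 by methyl in place of hydrogen on a saturated chain carbon bound to an oxygen on an aromatic ring. Going by the values given here, no measured step bears on that change, and because the limit of > 200000 nM in this assay, at which 2 of the 2 values shown sit, there is no number to move from. Compound 3 is therefore expected to stay at the limit, the estimated step that the limit leaves unreadable from compound 2 to compound 3 meaning nothing beyond the scatter. The estimate for compound 3 is 300000 nM, between 150000 nM and 1000000 nM.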

Compound 3, half-maximal inhibitory concentration: > 200000 nM
Compound 3: no number, only a limit; the forecaster's own chance of this, stated with the estimate: 90%; the middle value is on the limit's open side.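

Compound 3 also stands at a limit, so neither its step from compound 1 nor its step from compound 2 can be read: the limit of > 200000 nM in this assay, at which 3 of the 3 values shown sit. In this assay the compounds shown leave open how large any of these steps is.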